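Cytotoxicity notes: from compound 1 to compound 4

This account rests on a few compounds, and the source may have more. Where it says the series, first, only, none or still open, it means among the compounds named here.

Measured so far:
compound 1 `CCC1(Cc2ccccc2)OS(=O)(=O)C=C1OCC(=O)OC` — > 400000 nM
compound 2 `CC(C)CC1(Cc2ccccc2)OS(=O)(=O)C=C1OCc1ccccc1` — >= 80000 nM
compound 3 `CCC1(Cc2ccccc2)OS(=O)(=O)C=C1OC(c1ccccc1)c1ccccc1` — >= 80000 nM

All three readings in an ADME assay on HEL cells (Homo sapiens) for cytotoxicity, with a stated time of 3 days (on this read-out higher numbers stand for lower toxicity in this test and lower numbers for higher toxicity in this test), are limits of the test rather than numbers. Compound 1 sits at the limit of > 400000 nM in this assay, at which 1 of the 3 values shown sits. Compound 2 sits at the limit of >= 80000 nM in this assay, at which 2 of the 3 values shown sit. Compound 3 sits at the same limit, (the limit of >= 80000 nM in this assay, at which 2 of the 3 values shown sit). Compound 1 therefore stands at the less toxic of the two limits reached, and no measured step between any pair of these compounds exists; the three readings only show that none reached a measurable toxic concentration.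

Compound 4 `CCC1(Cc2ccccc2)OS(=O)(=O)C=C1OCc1ccc([N+](=O)[O-])cc1` remains to be measured in this assay. Its difference from compound 1 is 4-nitrophenyl in place of methoxycarbonyl on a saturated chain carbon bound to an oxygen on an unsaturated carbon. Among the measured compounds shown here, with no measured step available, the expectation in this assay is for no change beyond the usual scatter, since each measured compound stays at a limit.

Compound 4 is expected to give about 200000 nM, within 50000 nM to 800000 nM. The expected step is an at least 2.0-fold lower number from compound 1 to compound 4 (0.30 log units; that floor lies within the scatter), and a further limit reading is considered the most likely outcome.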

Compound 4, minimum cytotoxic concentration: >= 80000 nM
Compound 4 gave a limit, no number (the forecaster's own chance of this, stated with the estimate: 80%); the middle value does not contradict the limit.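

Among the compounds shown here, compound 1 and compound 4 both give limits in this assay, and no step between them can be read. The compounds shown leave open whether 4-nitrophenyl in place of methoxycarbonyl changes the minimum cytotoxic concentration at all, and at what concentration either compound would become toxic in this assay.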